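Series notes: relocating the amidoxime on the anilino arm

A few compounds are considered here, and "the series" means these few. Any claim that something is new, unique, unknown or untested is made for them only; others in the source may bear on it.

Going by the values given here, compound 2 `N/C(=N\O)c1ccc(Nc2ccc(C3=C(S(=O)(=O)c4ccc(/C(N)=N/O)cc4)CC(c4ccccc4)(c4ccccc4)O3)cc2)cc1` gives the highest of the three numbers so far in an ADME assay on THP-1 cells (Homo sapiens) for cytotoxicity, read by flow cytometry, with a stated time of 72 h (a higher number here means a weaker inhibitor, a lower number a stronger inhibitor), with 48900 nM. Compound 1 `N/C(=N\O)c1ccc(S(=O)(=O)C2=C(c3ccccc3)OC(c3ccccc3)(c3ccccc3)C2)cc1` sits nearest with 37900 nM, and the step of a 1.3-fold higher number from compound 1 to compound 2 (0.11 log units; within the scatter) shows that attaching the anilino amidoxime arm changed little. Compound 3 `CC1(Cc2ccccc2)CC(S(=O)(=O)c2ccc(/C(N)=N/O)cc2)=C(c2ccc(Nc3ccc(/C(N)=N/O)cc3)cc2)O1` is furthest, at 9800 nM. Compound 4 `N/C(=N\O)c1ccc(S(=O)(=O)C2=C(c3ccc(Nc4ccccc4/C(N)=N/O)cc3)OC(c3ccccc3)(c3ccccc3)C2)cc1` keeps every atom of compound 2 but joins them differently: a group of 10 heavy atoms (7 carbon, 2 nitrogen, 1 oxygen; one six-membered aromatic ring of carbon only) in place of a group of 10 heavy atoms (7 carbon, 2 nitrogen, 1 oxygen; one six-membered aromatic ring of carbon only), on a nitrogen on an aromatic ring. Among the compounds with values here, no measured step addresses such a rearrangement; the only step available, from compound 1 to compound 2, was within the scatter, so a change of similar size, in no particular direction, is expected here. The estimated step of a 1.2-fold lower number from compound 2 to compound 4 (0.09 log units; within the scatter) is therefore expected to stay within the scatter. For compound 4 the expected value in this assay is 40000 nM, with a range of 15000 nM to 110000 nM.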

Compound 4, half-maximal inhibitory concentration: 47800 nM
For compound 4 the middle estimate is 1.2-fold (0.08 log units) below the measured one, within the range that was stated.
By their numbers in this assay, from the lowest: compound 3; then compounds 1, 4 and 2 (each within the scatter of the next).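

In this assay, going by these compounds alone, rearranging the group on a nitrogen on an aromatic ring gives a 1.0-fold lower number from compound 2 to compound 4 (0.01 log units; within the scatter) and stays within the scatter, so this position shows no response to a change in how the same atoms are joined, which no earlier step could show. Against the core of compound 1, the rearranged arm gives a 1.3-fold higher number from compound 1 to compound 4 (0.10 log units; within the scatter) and is also within the scatter, so neither arrangement of the arm separates from the armless compound.

As far as these compounds go, whether a carboxylic acid or a primary amine in place of the amidoxime on this arm would also leave the number unchanged remains open. Nothing measured here bears on why these numbers stay together.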